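The source may hold more compounds than are shown below. What is called first, only, known or untested is meant among the compounds shown, and "the series" means these compounds.

Measured compounds:
- compound 1 `Clc1cccc(-n2ncnc2Nc2ccccc2)c1Cl` — 363 nM
- compound 2 `Cc1ccccc1Nc1ncnn1-c1cccc(Cl)c1Cl` — 17.8 nM
- compound 3 `Clc1cccc(-n2ncnc2NCc2ccccc2)c1Cl` — 47.9 nM

In a functional assay for antagonist activity at P2X purinoceptor 7 (Homo sapiens), read by FLIPR and calcium flux (a higher number here means a weaker inhibitor, a lower number a stronger inhibitor), compound 3 gives the second highest number of the three. Its nearest neighbour is compound 2, with a 2.7-fold higher number from compound 2 to compound 3 (0.43 log units; beyond the scatter) separating them; the furthest is compound 1, from which a 7.6-fold lower number from compound 1 to compound 3 (0.88 log units; beyond the scatter) leads to compound 3.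

Compound 4 `Cc1ccccc1CNc1ncnn1-c1cccc(Cl)c1Cl` has not been measured. It differs from compound 3 by methyl in place of hydrogen on an aromatic carbon; the methyl sits ortho to a large group, and cut one bond further out the difference reads phenyl to 2-methylphenyl.

The same change has been made once within the series, on the phenyl of compound 1 rather than on a benzyl: a 20-fold lower number from compound 1 to compound 2 (1.31 log units; beyond the scatter), a large drop. Going by the values given here, no measured step shows whether the effect carries over when the ring is held by an extra carbon. Among the compounds with values here, the expectation is therefore a fall in this assay for compound 4, most likely smaller than the one from compound 1 to compound 2, so an estimated 5.3-fold lower number from compound 3 to compound 4 (0.73 log units; beyond the scatter).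

The estimate for compound 4 in this assay is 9 nM, with a range from 3 nM to 30 nM.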

Compound 4, half-maximal inhibitory concentration: 20.9 nM
Estimate against measurement, compound 4: 2.3-fold (0.37 log units) below; measured number inside the range.
By their numbers in this assay, from the lowest: compounds 2 and 4 (each within the scatter of the next); then compound 3; then compound 1.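

In this assay the methyl still lowers the number when the ring is held as a benzyl group, but a 2.3-fold lower number from compound 3 to compound 4 (0.36 log units; beyond the scatter) is a much smaller step than the one made on the core of compound 1. The size of the change from phenyl to 2-methylphenyl thus depends on what connects the ring to the shared core, and two measured cases now differ clearly: the same change on two cores in this assay, a 20-fold lower number (1.31 log units; beyond the scatter) from compound 1 to compound 2 and a 2.3-fold lower number (0.36 log units; beyond the scatter) from compound 3 to compound 4, 8.9-fold (0.95 log units) apart, beyond the scatter of two such steps. With the methyl present, compound 2 at 17.8 nM and compound 4 at 20.9 nM lie within the scatter of each other, whereas a 7.6-fold lower number from compound 1 to compound 3 (0.88 log units; beyond the scatter) separates the pair without it.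

From the compounds shown here alone, whether ethyl, methoxy or an amine at the same place on the ring would follow the methyl, in either of the two series, remains open. Also open is how a longer chain in place of the benzyl connection would respond to the same methyl, since only two connections are shown and two pairs support no general rule.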